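Extending the chain of compound 2 by one carbon

The source may report more compounds than this note shows. Statements on the series, on what has been measured and on what is new or still open speak of the compounds shown alone.

Measured so far in a functional assay on A549 cells (Homo sapiens) for antiproliferative activity, read by MTT assay, with a stated time of 48 h (on this read-out higher numbers stand for weaker inhibition and lower numbers for stronger inhibition), for this series
- compound 1 `CCN(CC)CCCn1c(N)c(-c2nc3ccccc3[nH]2)c2nc(C#N)c(C#N)nc21` gives 25300 nM as a numerical value
- compound 2 `CCN(CC)CCn1c(N)c(-c2nc3cc(Cl)ccc3[nH]2)c2nc(C#N)c(C#N)nc21` gives > 50000 nM as a limit of the assay

Compound 2 therefore has no numerical value on this read-out, only a limit.

Compound 3 `CCN(CC)CCCn1c(N)c(-c2nc3cc(Cl)ccc3[nH]2)c2nc(C#N)c(C#N)nc21` differs from compound 2 by a single change, ((diethylamino)methyl in place of diethylamino on a saturated chain carbon, two bonds along the chain from an aromatic nitrogen), which turns the 2-(diethylamino)ethyl chain into 3-(diethylamino)propyl. Going by the values given here, no measured pair shows this change alone. Among the compounds with values here, compound 1 carries the same 3-(diethylamino)propyl chain and gives 25300 nM as the only numerical guide. Stronger inhibition is thus expected, though of uncertain size, and the expected change in this assay is an at least 1.9-fold lower number from compound 2 to compound 3 (0.28 log units; that floor lies within the scatter) in that direction. The estimate for compound 3 is 26000 nM in an expected range from 9000 nM to 50000 nM on this read-out.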

Compound 3, half-maximal inhibitory concentration: > 50000 nM
Compound 3 was reported as a limit; the forecaster's own chance of this, stated with the estimate: 30%; middle value at least 1.9-fold (0.28 log units) away from the limit.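

In this assay, the 3-(diethylamino)propyl chain does not bring the chloro series to a numerical value, as compound 3 is also reported only as a limit of the assay. The chain change itself cannot be read, because compound 2 and compound 3 both stand at the same limit: the limit of > 50000 nM in this assay, at which 2 of the 3 values shown sit. Going by these compounds alone, the one readable comparison is on the aromatic carbon, where chloro in place of hydrogen gives an at least 1.9-fold higher number from compound 1 to compound 3 (0.29 log units; that floor lies within the scatter), so with the 3-(diethylamino)propyl chain held constant the chloro compound shows no gain in inhibition, though the true size of the step stays unknown.

Going by these compounds, whether the chain length matters at all remains open. Also open, on these data alone, is how a fluoro or methoxy group on that aromatic carbon, or a morpholine in place of diethylamino, would read.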